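Amino for trifluoromethyl on compound 2

This account rests on a few compounds, and the source may have more. Where it says the series, first, only, none or still open, it means among the compounds named here.

In an in vitro ADME assay on microsomes from liver (Rattus norvegicus) for metabolic stability (on this read-out lower numbers stand for slow clearance and higher numbers for fast clearance), compound 1 `Cc1nc(Cn2c(=O)[nH]c3c(N)nc(C(F)(F)F)cc32)cs1` gives < 10 mL.min-1.g-1 as a limit and not a number. Compound 2 `Nc1nc(C(F)(F)F)cc2c1[nH]c(=O)n2Cc1ccc(C(F)(F)F)nc1` stands at < 8.5 mL.min-1.g-1 as a limit as well, with no exact number. Neither value is exact, so no order between the two compounds can be read from them.

Compound 3 `Nc1ccc(Cn2c(=O)[nH]c3c(N)nc(C(F)(F)F)cc32)cn1` differs from compound 2 by amino in place of trifluoromethyl on an aromatic carbon, next to the ring nitrogen and para to a large group (amino in place of trifluoromethyl on an aromatic carbon). Within the data shown here, the series holds no measured step for this change in this assay and none between its two measured compounds. The expectation is therefore no change beyond the scatter, in either direction. An estimated step that the limit leaves unreadable from compound 2 to compound 3 is expected. Compound 3 is expected at 8 mL.min-1.g-1 with an estimated range of 4 mL.min-1.g-1 to 18 mL.min-1.g-1 in this assay. Compound 3 may again give only a limit.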

Compound 3, intrinsic clearance in microsomes: < 10 mL.min-1.g-1
Compound 3: only a limit was reported; the forecaster's own chance of this, stated with the estimate: 60%; the middle value does not contradict the limit.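

In this assay compound 3 gives < 10 mL.min-1.g-1, a limit and not a number. Among these compounds, no step from compound 1 or compound 2 to compound 3 can be read. As far as these compounds go, the order of the three compounds, and the size of any effect of amino in place of trifluoromethyl, stay open.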